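Moving a Chlorine Around a Ring: Compound 1 to 4

This account rests on a few compounds, and the source may have more. Where it says the series, first, only, none or still open, it means among the compounds named here.

Measured so far in a functional assay on HCT-15 cells (Homo sapiens) for cytotoxicity, read by sulforhodamine B assay, with a stated time of 72 h; on this read-out higher numbers stand for weaker inhibition of growth and lower numbers for stronger inhibition of growth:
- compound 1 `O=C(Nc1ccccc1C(F)(F)F)C1CCc2ccccc2N1C(=O)c1cccc(Cl)c1` gives 797 nM
- compound 2 `O=C(Nc1cc(C(F)(F)F)cc(C(F)(F)F)c1)C1CCc2ccccc2N1C(=O)c1ccc(Cl)cc1` gives 2220 nM
- compound 3 `O=C(Nc1ccccc1O)C1CCc2ccccc2N1` gives 5610 nM

Compound 1 is the strongest of the three, as its gaps to compound 2 and to compound 3 both lie beyond the usual scatter. The next compound, compound 4 `O=C(Nc1ccccc1C(F)(F)F)C1CCc2ccccc2N1C(=O)c1ccccc1Cl`, keeps every atom of compound 1 and changes only the way they are joined: 2-chlorophenyl in place of 3-chlorophenyl on a carbonyl carbon. Among the measured compounds shown here, no pair of compounds measured here differs by this kind of change, so nothing shows how much it matters. The step from compound 1 to compound 4 is expected to be small, most likely within the scatter, in either direction: a 1.1-fold higher number from compound 1 to compound 4 (0.05 log units; within the scatter). Compound 4 is therefore estimated at 900 nM, in a range from 300 nM to 2700 nM.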

Compound 4, concentration for 50% growth inhibition: 4220 nM
Compound 4: the middle estimate sits 4.7-fold (0.67 log units) below what was measured; the measured number lies above the stated range.
By their numbers in this assay, from the lowest: compound 1; then compounds 2, 4 and 3 (each within the scatter of the next, the first and the last beyond it).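

In this assay the swap of 3-chlorophenyl for 2-chlorophenyl on a carbonyl carbon gives a 5.3-fold higher number from compound 1 to compound 4 (0.72 log units; beyond the scatter) with the same atoms throughout, so where the chlorine sits on the phenyl group clearly matters for growth inhibition. Among the compounds shown here, this pair is the first direct sign that this part of the molecule responds to change, and the 3-chlorophenyl form is the stronger of the two. Nothing available explains the loss.

Still open, from the compounds shown here alone, is how 4-chlorophenyl would compare with all else in compound 1 kept. Also open, going by these compounds, is what a methoxy group or a nitrile would do in place of the chlorine.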